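From Benzyl to Propyl: Estimating Compound 4

The source may report more compounds than this note shows. Statements on the series, on what has been measured and on what is new or still open speak of the compounds shown alone.

Compound 1 `C=CCN(CC=C)c1nc(C)nc(Nc2c(C)cc(C)cc2C)n1`: 115 nM
Compound 3 `CCCN(Cc1ccccc1)c1nc(C)nc(Nc2c(C)cc(C)cc2C)n1`: 490 nM
Compound 2 `CCCN(Cc1ccccc1)c1nc(C)nc(Nc2ccc(C)cc2)n1`: reported only as the limit > 10000 nM

In an assay on isolated protein for binding affinity to corticotropin-releasing factor receptor 1 (Homo sapiens) (on this read-out lower numbers stand for stronger inhibition and higher numbers for weaker inhibition), compound 3 holds the highest of the two numbers; compound 1 sits a clear step lower, beyond the scatter. Compound 2 reaches only the limit (the limit of > 10000 nM in this assay, at which 1 of the 3 values shown sits). Among the compounds with values here, the single measured step, an at least 20-fold lower number from compound 2 to compound 3 (1.30 log units; beyond the scatter), concerns the aryl on the ring nitrogen, not the position changed here, so no measured step bears directly on the change. Compound 4 `CCCN(CCC)c1nc(C)nc(Nc2c(C)cc(C)cc2C)n1` differs from compound 3 by ethyl in place of phenyl on a saturated chain carbon bound to a nitrogen on an aromatic ring. Since compound 1, bearing two small chains, gives 115 nM, a modest move toward lower numbers is expected, a 2.5-fold lower number from compound 3 to compound 4 (0.39 log units; beyond the scatter). Compound 4 is thus estimated at 200 nM, within 60 nM to 800 nM.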

Compound 4, inhibition constant: 130 nM
For compound 4 the middle estimate is 1.5-fold (0.19 log units) above the measured one; measured number inside the range.
By their numbers in this assay, from the lowest: compounds 1 and 4 (each within the scatter of the next); then compound 3. At a limit, above all of these: compound 2.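

In this assay the change from benzyl to propyl gives a 3.8-fold lower number from compound 3 to compound 4 (0.58 log units; beyond the scatter), so a phenyl at this place is not required, and the smaller ethyl in its place does better. Dipropylamino in place of diallylamino gives a 1.1-fold higher number from compound 1 to compound 4 (0.05 log units; within the scatter), so these two small chains cannot be told apart on this read-out. The compounds shown leave open whether a longer chain such as butyl, or a propyl chain ending in a hydroxyl or an amine, would hold this level. Nothing shown accounts for the step from benzyl to propyl.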